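Halogen Back in Place: From Formyl to Chloro

The source may hold more compounds than are shown below. What is called first, only, known or untested is meant among the compounds shown, and "the series" means these compounds.

Compound 3 `O=Cc1ccc(O)c(C(=O)Nc2ccc(C(F)(F)F)cc2)c1` carries a formyl group where compound 2 `O=C(Nc1ccc(C(F)(F)F)cc1)c1cc(Br)ccc1O` carries bromo. In a functional assay on HepG2 cells (Homo sapiens) for cytotoxicity, read by MTT assay, with a stated time of 24 h (on this read-out lower numbers stand for stronger inhibition and higher numbers for weaker inhibition), compound 3 gives 17600 nM, the highest of the two numbers shown; compound 2 gives 5500 nM. Compound 1 `C/C(=N\OCC(=O)N[C@H](C(=O)N[C@@H](CCCCN)C(=O)N1CCC[C@H]1C(=O)N1CCC[C@@H]1C(=O)N[C@H](CCCNC(=N)N)C(=O)O)[C@@H](C)O)c1ccc(NC(=O)c2cc(Br)ccc2O)cc1` reaches only a limit of the assay, > 200000 nM, which is the limit of > 200000 nM in this assay, at which 1 of the 3 values shown sits, and not a number.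

Going by the values given here, the one measured step that bears on the question is a 3.2-fold higher number from compound 2 to compound 3 (0.51 log units; beyond the scatter). Compound 4 `O=C(Nc1ccc(C(F)(F)F)cc1)c1cc(Cl)ccc1O` differs from compound 3 in the way (chloro in place of formyl on an aromatic carbon); this change undoes the earlier exchange in kind, a halogen again standing in place of the formyl, though chloro rather than bromo. The expectation is therefore a step back toward the number of compound 2, that is a lower number for compound 4 than for compound 3, of about the size seen from compound 2 to compound 3.

In this assay compound 4 is expected to give 7000 nM, estimated between 3000 nM and 17000 nM, corresponding to an expected step of a 2.5-fold lower number from compound 3 to compound 4 (0.40 log units; beyond the scatter).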

Compound 4, half-maximal inhibitory concentration: 5800 nM
Compound 4: the middle estimate sits 1.2-fold (0.08 log units) above what was measured, within the range that was stated.
By their numbers in this assay, from the lowest: compounds 2 and 4 (each within the scatter of the next); then compound 3. At a limit, above all of these: compound 1.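

With chloro in place of formyl, a 3.0-fold lower number from compound 3 to compound 4 (0.48 log units; beyond the scatter) in this assay, so the higher number of compound 3 is not shared by a second halogen at this position. The comparison of the two halogens adds what compound 2 alone could not show: a 1.1-fold higher number from compound 2 to compound 4 (0.02 log units; within the scatter), so chloro and bromo, para to a hydroxy group, cannot be told apart in this assay, and the exchange of formyl for halogen does not depend on which of these two halogens is present. Nothing measured here accounts for the gap between the halogens and the formyl group.

The compounds shown leave open where an amine, a carboxylic acid or a methoxy group at this position would fall relative to formyl and the halogens. They also leave open whether fluoro or iodo would match chloro and bromo.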